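From Amino to Methoxy on the Aryl Ketone

This account rests on a few compounds, and the source may have more. Where it says the series, first, only, none or still open, it means among the compounds named here.

Compound 2 `COc1cc(-c2cc(/C=C/C(=O)c3ccc(N)cc3)[nH]n2)cc(OC)c1OC` gives -19% in a functional assay on 786-0 cells (Homo sapiens) for cytotoxicity, read by sulforhodamine B assay, with a stated time of 48 h, tested at 10 uM; on this read-out lower numbers stand for a stronger effect and higher numbers for a weaker effect at the one concentration tested. Compound 1 `COc1ccc(-c2cc(/C=C/C(=O)c3ccc(N)cc3)[nH]n2)cc1` gives -29%, within the scatter of compound 2, while compound 3 `COc1cc(-c2cc(/C=C/C(=O)c3ccc(Cl)c(Cl)c3)[nH]n2)cc(OC)c1OC` gives 50%, so compound 2 stands second highest of the three. Compound 4 `COc1ccc(C(=O)/C=C/c2cc(-c3cc(OC)c(OC)c(OC)c3)n[nH]2)cc1` differs from compound 2 by methoxy in place of amino on an aromatic carbon. Among the compounds with values here, no measured step makes exactly this change; the one that bears on it is a number 69 percentage points higher from compound 2 to compound 3 (beyond the scatter), which also removes the 4-aminophenyl group but puts in a different one. On that basis a rise in this assay is expected for compound 4, though a smaller one, estimated as a number 39 percentage points higher from compound 2 to compound 4 (beyond the scatter). Compound 4 is therefore expected to give about 20%, somewhere between -15% and 55%.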

Compound 4, a percentage reported as activity, at one concentration (the size of the read-out at that concentration, not a potency): -59%
The estimate for compound 4 lay 79 percentage points above the measured number; the measured number lies below the stated range.
By their numbers in this assay, from the lowest: compound 4; then compounds 1 and 2 (each within the scatter of the next); then compound 3.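

Swapping amino for methoxy gives a number 40 percentage points lower from compound 2 to compound 4 (beyond the scatter) in this assay, so losing the 4-aminophenyl group does not by itself weaken the effect. The weak result seen earlier belongs to the 3,4-dichlorophenyl group specifically and not to the absence of amino, as a number 109 percentage points lower from compound 3 to compound 4 (beyond the scatter) shows on the same core. The group on this carbonyl carbon can therefore move the read-out in either direction.

On these data alone, whether a hydroxyl or a dimethylamino group here would behave like methoxy remains open. Nothing available explains why methoxy and 3,4-dichlorophenyl differ so widely.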